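Compound 2 to compound 4: replacing dimethylamino with methyl

A few compounds are considered here, and "the series" means these few. Any claim that something is new, unique, unknown or untested is made for them only; others in the source may bear on it.

Among the compounds with values here, in a functional assay on A549 cells (Homo sapiens) for antiproliferative activity, read by MTT assay, with a stated time of 72 h (a higher number here means a weaker inhibitor, a lower number a stronger inhibitor), compound 1 `CNc1nc(-c2cc(OC)c(OC)c(OC)c2)c(-c2ccc(C(F)(F)F)cc2)s1` gives 4570 nM, the only actual number so far. Compound 2 `COc1cc(-c2nc(N(C)C)sc2-c2ccc(C(F)(F)F)cc2)cc(OC)c1OC` gives > 10000 nM, which is a limit and not a number. Compound 3 `CCOc1ccc(-c2sc(N(C)C)nc2-c2cc(OC)c(OC)c(OC)c2)cc1` gives > 10000 nM, which is also a limit.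

Compound 4 `COc1cc(-c2nc(C)sc2-c2ccc(C(F)(F)F)cc2)cc(OC)c1OC` carries methyl in place of dimethylamino on an aromatic carbon. Within the data shown here, no measured step makes this exact change. The closest is the replacement of hydrogen by methyl on the nitrogen of the same substituent, which gives an at least 2.1-fold higher number from compound 1 to compound 2 (0.34 log units; beyond the scatter). Ethoxy in place of trifluoromethyl gives a step that the two limits leave unreadable from compound 2 to compound 3, so it offers no guide to size. Losing dimethylamino could therefore move the number downward in this assay, but the size is poorly fixed, and another limit remains quite possible. The expected change is an at least 1.4-fold lower number from compound 2 to compound 4 (0.15 log units; that floor lies within the scatter). For compound 4, the estimated value is 7000 nM, with an expected range of 1500 nM to 20000 nM.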

Compound 4, half-maximal inhibitory concentration: 4290 nM
The estimate for compound 4 lay 1.6-fold (0.21 log units) above the measured number; the measured number falls inside the stated range.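

Within the data shown here, on the aromatic carbon of the five-membered aromatic ring with 1 nitrogen and 1 sulfur, methyl in place of dimethylamino gives, in this assay, an at least 2.3-fold lower number from compound 2 to compound 4 (0.36 log units; beyond the scatter), so the second alkyl group on the nitrogen is not the only change at this position that can separate a compound from the limit. Methyl and methylamino at this position cannot be told apart, with a 1.1-fold lower number from compound 1 to compound 4 (0.03 log units; within the scatter), so the nitrogen of methylamino is not needed to hold the value. Compound 2 gives > 10000 nM, which is a limit and not a number, and the step from it is known only as a floor: the limit of > 10000 nM in this assay, at which 2 of the 4 values shown sit.

From the compounds shown here alone, whether an unsubstituted amine or a longer chain such as ethyl at this position would differ beyond the scatter from compound 4 stays open. Going by these compounds, the step between the limits of compound 2 and compound 3 cannot be read, so ethoxy against trifluoromethyl also stays open.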